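Swapping the Methoxyphenyl for a Pyridinyl on the Amide Arm

A few compounds are considered here, and "the series" means these few. Any claim that something is new, unique, unknown or untested is made for them only; others in the source may bear on it.

Compound 1 `CN(C)CCN1CCN(C2=Nc3ccccc3C(CC(=O)NCc3ccccc3)N2c2ccc(-c3ccccc3)cc2)CC1` gives 1390 nM
Compound 2 `Cc1ccc(CNC(=O)CC2c3ccccc3N=C(N3CCN(CCN(C)C)CC3)N2c2ccc(-c3ccccc3)cc2)cc1` gives 1600 nM
Compound 3 `COc1ccc(CNC(=O)CC2c3ccccc3N=C(N3CCN(CCN(C)C)CC3)N2c2ccc(-c3ccccc3)cc2)cc1` gives 1440 nM

In a functional assay on A2780 cells (Homo sapiens) for cytotoxicity, read by MTT assay, with a stated time of 48 h (a higher number here means a weaker inhibitor, a lower number a stronger inhibitor), compound 3 stands second highest of the three numbers, with compound 1 nearest and compound 2 furthest, all three within the scatter of one another. Compound 4 `CN(C)CCN1CCN(C2=Nc3ccccc3C(CC(=O)NCc3ccccn3)N2c2ccc(-c3ccccc3)cc2)CC1` differs from compound 3 by pyridin-2-yl in place of 4-methoxyphenyl on a saturated chain carbon bound to an amide-type nitrogen. The measured steps all touch this same ring: a 1.2-fold higher number from compound 1 to compound 2 (0.06 log units; within the scatter), a 1.0-fold higher number from compound 1 to compound 3 (0.02 log units; within the scatter) and a 1.1-fold lower number from compound 2 to compound 3 (0.05 log units; within the scatter), each within the scatter. None of them replaces the ring itself with one holding a hetero atom, so the bearing is indirect, but each points to little sensitivity at this arm. No step beyond the scatter is therefore expected, with a widened range for the untested kind of change. Compound 4 is expected at 1500 nM, between 600 nM and 4000 nM, a step of a 1.0-fold higher number from compound 3 to compound 4 (0.02 log units; within the scatter).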

Compound 4, half-maximal inhibitory concentration: 4860 nM
For compound 4 the middle estimate is 3.2-fold (0.51 log units) below the measured one, and the stated range ends below it.
By their numbers in this assay, from the lowest: compounds 1, 3 and 2 (each within the scatter of the next); then compound 4.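

In this assay methyl and methoxy on the carbon-only ring left the number in place, but exchanging that ring for pyridin-2-yl shifts it beyond the scatter (a 3.4-fold higher number from compound 3 to compound 4 (0.53 log units; beyond the scatter); a 3.0-fold higher number from compound 2 to compound 4 (0.48 log units; beyond the scatter); a 3.5-fold higher number from compound 1 to compound 4 (0.54 log units; beyond the scatter)). This arm therefore responds to a change in the ring itself, even though it did not respond to these groups on the ring. Nothing available accounts for the shift. On these data alone, whether the place of the ring nitrogen matters stays open, and pyridin-3-yl or pyridin-4-yl on the same chain carbon would address it. As far as these compounds go, how a cyclohexyl group would behave there also stays open.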